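Cytotoxicity notes: cyano in place of fluoro, compound 4

This account rests on a few compounds, and the source may have more. Where it says the series, first, only, none or still open, it means among the compounds named here.

Measured in a functional assay on C6 cells (Rattus norvegicus) for cytotoxicity, read by MTT assay, with a stated time of 24 h, tested at 12 ug/mL; on this read-out higher numbers stand for a weaker effect at the one concentration tested and lower numbers for a stronger effect:
- compound 1 `Cc1nnc(SCC(=O)N/N=c2/scc(-c3ccc(F)cc3)n2-c2ccccc2)s1` gives 73.7%
- compound 2 `O=C(CSc1nnnn1-c1ccccc1)N/N=c1/scc(-c2ccc(F)cc2)n1-c1ccccc1` gives 60%
- compound 3 `O=C(CSc1ncccn1)N/N=c1/scc(-c2ccc(F)cc2)n1-c1ccccc1` gives 77.4%

Compound 2 stands lowest of the three numbers, and both of its neighbours lie beyond the scatter: a number 13.7 percentage points lower from compound 1 to compound 2 (beyond the scatter), and a number 17.4 percentage points higher from compound 2 to compound 3 (beyond the scatter). Between compound 1 and compound 3 the step is a number 3.7 percentage points higher from compound 1 to compound 3 (within the scatter), so those two cannot be ordered.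

Compound 4 `N#Cc1ccc(-c2cs/c(=N/NC(=O)CSc3nnnn3-c3ccccc3)n2-c2ccccc2)cc1` is the next member. Compared with compound 2 the change is cyano in place of fluoro on an aromatic carbon. Going by the values given here, every measured step so far alters only the group on the sulfur; none touches the fluorophenyl ring, so none of them bears directly on this change. Among the compounds with values here, with no measured precedent for it, the working expectation is a step of no more than the usual scatter in this assay, in either direction; the expected step is a number 2 percentage points higher from compound 2 to compound 4 (within the scatter). Compound 4 is therefore estimated at 62%, with a range from 46% to 78%.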

Compound 4, a percentage reported as activity, at one concentration (the size of the read-out at that concentration, not a potency): 74.1%
The estimate for compound 4 lay 12.1 percentage points below the measured number; the measured number falls inside the stated range.
By their numbers in this assay, from the lowest: compound 2; then compounds 1, 4 and 3 (each within the scatter of the next).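

Going by these compounds alone, this is the first measured change on the fluorophenyl ring, and in this assay replacing 4-fluorophenyl with 4-cyanophenyl gives a number 14.1 percentage points higher from compound 2 to compound 4 (beyond the scatter), so this position on the aromatic carbon affects the read-out as well as the group on the sulfur. The stronger effect of compound 2 therefore does not rest on the 1-phenyl-1H-tetrazol-5-yl group alone, since compound 4 keeps that group and gives 74.1% at the one concentration tested. Nothing at hand accounts for this step.

The compounds shown leave open whether the cyano for fluoro change has a similar effect with 5-methyl-1,3,4-thiadiazol-2-yl or pyrimidin-2-yl on the sulfur. They also leave open how other groups at this ring position, such as an amine or a carboxylic acid, would read here.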